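Pyrazolyl sulfonohydrazide: removing the ring fluorine

A few compounds are considered here, and "the series" means these few. Any claim that something is new, unique, unknown or untested is made for them only; others in the source may bear on it.

Measured compounds:
compound 1 `O=C(NNS(=O)(=O)c1ccccc1F)c1cc(F)cc(-n2cccn2)c1` — 18 uL/min
compound 2 `O=C(NNS(=O)(=O)c1ccccc1F)c1cc(F)cc(-c2ccccn2)c1` — 31 uL/min

Working notes on the series. In an ADME assay on microsomes from liver (Homo sapiens) for metabolic stability, read by HPLC, using NADPH, with a stated time of 60 min, tested at 1 uM, in the presence of a further agent that is not named here (on this read-out lower numbers stand for slow clearance and higher numbers for fast clearance), compound 1 gives 18 uL/min and compound 2 gives 31 uL/min. Compound 1 therefore carries the lower of the numbers shown, though the step of a 1.7-fold higher number from compound 1 to compound 2 (0.24 log units; within the scatter) is within the scatter, so the pair is treated as level.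

Compound 3 `O=C(NNS(=O)(=O)c1ccccc1F)c1cccc(-n2cccn2)c1` is not yet measured in this assay. It differs from compound 1 in one place: hydrogen in place of fluoro on an aromatic carbon. Among the compounds with values here, the only measured step, a 1.7-fold higher number from compound 1 to compound 2 (0.24 log units; within the scatter), concerns an exchange of the five-membered ring for pyridin-2-yl and does not touch the fluoro, so no measured step bears directly on this change. Within the data shown here, the data therefore give no direction for it; the only anchor is the value of compound 1 itself.

On that basis compound 3 is expected to stay close to compound 1, with a step of a 1.2-fold higher number from compound 1 to compound 3 (0.09 log units; within the scatter) that lies within the scatter. The estimate for compound 3 in this assay is 22 uL/min, with a range from 11 uL/min to 44 uL/min.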

Compound 3, intrinsic clearance in a liver preparation (reported as CLH), per the amount of preparation that the assay uses in the Homo sapiens assay: 12 uL/min
Estimate against measurement, compound 3: 1.8-fold (0.26 log units) above, and the stated range covers the measured number.
By their numbers in the Homo sapiens assay, from the lowest: compounds 3, 1 and 2 (each within the scatter of the next, the first and the last beyond it).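

Within the data shown here, with the Homo sapiens assay as the read-out, the step of a 1.5-fold lower number from compound 1 to compound 3 (0.18 log units; within the scatter) gives the first direct reading on this aromatic carbon, and it shows that the core of compound 1 keeps its number within the usual spread when the fluoro gives way to hydrogen. In a physicochemical assay for solubility, read by nephelometry, in phosphate buffer, measured as kinetic solubility, at pH 6.5 (a higher number here means a more soluble compound, a lower number a less soluble compound), compound 1 gives 25 ug/mL and compound 3 gives 50 ug/mL with a 2.0-fold higher number from compound 1 to compound 3 (0.30 log units; within the scatter) as the step, so neither read-out separates the pair and the fluoro is not required to hold either number in this range. Nothing at hand offers an explanation for these readings.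

Whether a chloro, a methoxy or an amine on this aromatic carbon would also stay within the spread of compound 1 remains open, since fluoro and hydrogen are the only two groups shown here. Also open, going by these compounds, is whether hydrogen in place of fluoro would give a similar step with pyridin-2-yl as the ring group, as the present reading rests on the 1H-pyrazol-1-yl pair alone.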